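A few compounds are considered here, and "the series" means these few. Any claim that something is new, unique, unknown or untested is made for them only; others in the source may bear on it.

Compounds measured in a functional assay on the whole organism with Rattus norvegicus as the target, at a dose of 1 mg/kg by the oral route (a lower number here means a weaker effect, a higher number a stronger effect of the compound at the dose given), so far:
compound 1 `COc1cc(C(=O)Nc2nn[nH]n2)nc(-c2ccc(C)cc2)c1`, 42%
compound 2 `CCc1ccc(-c2cc(OC)cc(C(=O)Nc3nn[nH]n3)n2)cc1`, 43%

Compound 2 stands highest of the two numbers, yet its nearest neighbour compound 1 sits a number 1 percentage points higher from compound 1 to compound 2 (within the scatter), so the two are indistinguishable. Compound 3 `COc1cc(C(=O)Nc2nn[nH]n2)nc(-c2ccc(N(C)C)cc2)c1` differs from compound 2 by dimethylamino in place of ethyl on an aromatic carbon. Among the measured compounds shown here, no measured step touches this position with such a group; the single step known, a number 1 percentage points higher from compound 1 to compound 2 (within the scatter), concerns a different change and gives no lead. Compound 3 is therefore expected near compound 2, with a step of a number 1 percentage points lower from compound 2 to compound 3 (within the scatter), and an estimated value of 42% within 25% to 60%.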

Compound 3, a percentage reported as inhibition, in the whole organism at one dose (the size of the read-out at that dose, not a potency): 64%
The estimate for compound 3 lay 22 percentage points below the measured number; the measured number lies above the stated range.
By their numbers in this assay, from the lowest: compounds 1 and 2 (each within the scatter of the next); then compound 3.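

In this assay this position, on an aromatic carbon para to a large group, responds to the group it carries: dimethylamino in place of ethyl gives a number 21 percentage points higher from compound 2 to compound 3 (beyond the scatter) and dimethylamino in place of methyl gives a number 22 percentage points higher from compound 1 to compound 3 (beyond the scatter) as well. Compound 1 and compound 2 stay within the scatter of each other, so the two alkyl groups do not separate, while dimethylamino stands clear of both. Nothing available explains this gain.

On these data alone, whether the nitrogen of dimethylamino or its two methyl groups carry the gain stays open. A primary amine, diethylamino or methoxy at this position would bear on that question.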